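Boronic ester chalcones on L929 cells: a trio

This account rests on a few compounds, and the source may have more. Where it says the series, first, only, none or still open, it means among the compounds named here.

Compound 1 `O=C(/C=C/c1ccc2c(c1)B(O)OC2)c1ccccn1`: > 10 ug/mL
Compound 2 `COc1cc(C(=O)/C=C/c2ccc3c(c2)B(O)OC3)cc(OC)c1OC`: > 10 ug/mL

In an ADME assay on L929 cells (Mus musculus) for cytotoxicity, read by resazurin assay, with a stated time of 72 h (a lower number here means a stronger inhibitor, a higher number a weaker inhibitor), compound 1 gives only a limit, > 10 ug/mL. Compound 2 likewise gives only a limit in this assay, > 10 ug/mL. Within the data shown here, both values therefore sit at the limit of > 10 ug/mL in this assay, at which 2 of the 2 values shown sit, and no measured step exists between them. Compound 3 `Nc1ccc(C(=O)/C=C/c2ccc3c(c2)B(O)OC3)cc1` differs from compound 1 by 4-aminophenyl in place of pyridin-2-yl on a carbonyl carbon. Among the measured compounds shown here, with no measured step available, the expected change in this assay is none beyond the scatter, so compound 3 is expected to remain near the limit. The estimate for compound 3 is 15 ug/mL, ranging from 7 ug/mL to 40 ug/mL, meaning an expected step that the limit leaves unreadable from compound 1 to compound 3.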

Compound 3, half-maximal inhibitory concentration: > 10 ug/mL
Compound 3: no number, only a limit; the forecaster's own chance of this, stated with the estimate: 75%; the middle value does not contradict the limit.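

In this assay compound 3 gives only a limit, > 10 ug/mL. Among these compounds, compound 1 also gives only a limit, so no step between compound 1 and compound 3 can be read. The compounds shown leave open where any of their actual values lies: the limit of > 10 ug/mL in this assay, at which 3 of the 3 values shown sit.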